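Swapping Furan for Thiophene on a Shared Core

A few compounds are considered here, and "the series" means these few. Any claim that something is new, unique, unknown or untested is made for them only; others in the source may bear on it.

Compound 1 `COC(=O)c1nc(-c2ccoc2)n(-c2ccc(F)cc2)n1`: 91600 nM
Compound 2 `COC(=O)c1nc(-c2ccsc2)n(-c2ccc(F)cc2)n1`: 6940 nM
Compound 3 `COC(=O)c1nc(-c2ccoc2)n(-c2ccc(C(F)(F)F)cc2)n1`: 6010 nM

All three compounds were tested in a functional assay on NCI-H226 cells (Homo sapiens) for inhibition, read by MTT assay, with a stated time of 72 h; a higher number here means a weaker inhibitor of growth, a lower number a stronger inhibitor of growth. Compound 1 gives the highest number, 91600 nM. Putting thiophen-3-yl where furan-3-yl stood, the change (thiophen-3-yl in place of furan-3-yl on an aromatic carbon), produces a 13-fold lower number from compound 1 to compound 2 (1.12 log units; beyond the scatter). The core of compound 3 differs from that of compound 1 by trifluoromethyl in place of fluoro on an aromatic carbon, and this alone produces a 15-fold lower number from compound 1 to compound 3 (1.18 log units; beyond the scatter). Compound 2 and compound 3 lie within the scatter of each other, so neither can be called the stronger of the two.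

Compound 4 `COC(=O)c1nc(-c2ccsc2)n(-c2ccc(C(F)(F)F)cc2)n1` has not been measured. It carries thiophen-3-yl in place of furan-3-yl on an aromatic carbon. Among the compounds with values here, this is the same kind of change as the one from compound 1 to compound 2, not the same change: in compound 3 the ring atom beside the place bears a large group, whereas in compound 1 it bears a 4-fluorophenyl group. A step of a 4.0-fold lower number from compound 3 to compound 4 (0.60 log units; beyond the scatter) is expected, smaller than the earlier one, because compound 3 already starts at 6010 nM rather than from the high number of compound 1. Compound 4 is estimated at 1500 nM, between 400 nM and 5000 nM.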

Compound 4, concentration for 50% growth inhibition: 5740 nM
For compound 4 the middle estimate is 3.8-fold (0.58 log units) below the measured one; measured number above the stated range.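

In this assay, neither change keeps its earlier size on the second core: thiophen-3-yl in place of furan-3-yl now gives a 1.0-fold lower number from compound 3 to compound 4 (0.02 log units; within the scatter), and trifluoromethyl in place of fluoro gives a 1.2-fold lower number from compound 2 to compound 4 (0.08 log units; within the scatter), so a step measured on one core cannot simply be added on another in this series, though four compounds cannot show why. For the swap of furan-3-yl for thiophen-3-yl, the two cores clearly disagree: the same change on two cores in this assay, a 13-fold lower number (1.12 log units; beyond the scatter) from compound 1 to compound 2 and a 1.0-fold lower number (0.02 log units; within the scatter) from compound 3 to compound 4, 13-fold (1.10 log units) apart, beyond the scatter of two such steps. The trifluoromethyl change shows the same disagreement: the same change on two cores in this assay, a 15-fold lower number (1.18 log units; beyond the scatter) from compound 1 to compound 3 and a 1.2-fold lower number (0.08 log units; within the scatter) from compound 2 to compound 4, 13-fold (1.10 log units) apart, beyond the scatter of two such steps.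

Compound 2, compound 3 and compound 4 cannot be told apart in this assay, and the compounds shown leave open whether any other change could move the number further from that shared level. They also leave open what a carboxylic acid or an amide in place of the methoxycarbonyl group, or chloro in place of trifluoromethyl, would do.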